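The source may report more compounds than this note shows. Statements on the series, on what has been measured and on what is new or still open speak of the compounds shown alone.

Going by the values given here, compound 2, `C=CC[C@@H]1C[C@@H](c2ccc(Cl)c(Cl)c2)[C@H](NC(=O)c2cc(-c3c(Cl)cnn3C)c(Cl)o2)CN1`, gives 12.4 nM in an assay for inhibition of RAC-alpha serine/threonine-protein kinase (Homo sapiens), read by HTRF, with a stated time of 1 h (a lower number here means a stronger inhibitor, a higher number a weaker inhibitor), the higher of the two numbers known; compound 1, `Cn1ncc(Cl)c1-c1cc(C(=O)N[C@@H]2CN[C@H](CCN3CCC(O)CC3)C[C@H]2c2ccc(Cl)c(Cl)c2)oc1Cl`, gives 5.99 nM. Among the compounds with values here, the only measured step bearing on the new change is a 2.1-fold higher number from compound 1 to compound 2 (0.32 log units; beyond the scatter). Compound 3, `CN(C)CC[C@@H]1C[C@@H](c2ccc(Cl)c(Cl)c2)[C@H](NC(=O)c2cc(-c3c(Cl)cnn3C)c(Cl)o2)CN1`, differs from compound 2 by (dimethylamino)methyl in place of vinyl on a saturated chain carbon bound to a saturated ring carbon, which brings a nitrogen-bearing group back onto that chain. Since the step from compound 1 to compound 2 was modest, a modest move in the opposite direction is expected, a 1.8-fold lower number from compound 2 to compound 3 (0.25 log units; within the scatter). Compound 3 is therefore estimated at 7 nM in this assay, with a range from 3.5 nM to 14 nM.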

Compound 3, half-maximal inhibitory concentration: 3.4 nM
For compound 3 the middle estimate is 2.1-fold (0.31 log units) above the measured one, and the stated range ends above it.
By their numbers in this assay, from the lowest: compounds 3 and 1 (each within the scatter of the next); then compound 2.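

In this assay, putting (dimethylamino)methyl in place of vinyl gives a 3.6-fold lower number from compound 2 to compound 3 (0.56 log units; beyond the scatter), so the lower number at this chain position does not depend on the 4-hydroxypiperidin-1-yl group. Dimethylamino in its place gives a 1.8-fold lower number from compound 1 to compound 3 (0.25 log units; within the scatter), which sets no order between the two amines. No evidence is available to explain these steps.

The compounds shown leave open whether the nitrogen itself matters, or whether a hydroxyl or methoxy group on the same chain would serve as well. They also leave open how a primary amine or a longer chain ending in dimethylamino would compare.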